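Replacing 3-bromophenyl with 4-fluorophenyl: what to expect

This account rests on a few compounds, and the source may have more. Where it says the series, first, only, none or still open, it means among the compounds named here.

Of the compounds shown here, three sharing one core have been tested so far in a functional assay on the whole organism (strain Kunming) with Mus musculus as the target, with a stated time of 0.5 h; a higher number here means that more compound is needed for the effect, a lower number that less compound is needed. Compound 1 `COc1cc(OC)c(OC)cc1/C=C/COC(=O)/C=C/c1ccc(OC)c(OC)c1` gives > 300 mg/kg, which is a limit of the assay and not a number. Compound 2 `COc1cc(OC)c(OC)cc1/C=C/COC(=O)/C=C/c1ccccc1C(F)(F)F` gives > 300 mg/kg, which is also a limit. Going by the values given here, compound 3 `COc1cc(OC)c(OC)cc1/C=C/COC(=O)/C=C/c1cccc(Br)c1` gives 215 mg/kg, the only true number among the three. The data are therefore dominated by the limit of > 300 mg/kg in this assay, at which 2 of the 3 values shown sit.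

Compound 4 `COc1cc(OC)c(OC)cc1/C=C/COC(=O)/C=C/c1ccc(F)cc1` has not yet been measured. It has 4-fluorophenyl in place of the 3-bromophenyl of compound 3, on a double-bonded chain carbon bound to a double-bonded chain carbon (4-fluorophenyl in place of 3-bromophenyl on a double-bonded chain carbon bound to a double-bonded chain carbon).

Two measured steps changed this same place: an at least 1.3-fold lower number from compound 1 to compound 3 (0.14 log units; that floor lies within the scatter) and an at least 1.3-fold lower number from compound 2 to compound 3 (0.14 log units; that floor lies within the scatter). Each gives only a floor, so neither shows how large a change here can truly be. Among the compounds with values here, no measured compound carries the 4-fluorophenyl group. In this assay, no step beyond the scatter is therefore expected, and a result at the limit would be no surprise. The expected change is a 1.2-fold higher number from compound 3 to compound 4 (0.07 log units; within the scatter). Compound 4 is estimated at 250 mg/kg, with an expected range from 110 mg/kg to 450 mg/kg.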

Compound 4, dose for half-maximal effect: > 300 mg/kg
Compound 4 ended at the assay's limit; the forecaster's own chance of this, stated with the estimate: 45%; middle value at least 1.2-fold (0.07 log units) from the limit.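

In this assay, going by these compounds alone, compound 3 remains the only compound of the four with a true number, 215 mg/kg, so 3-bromophenyl is still the only group at this position that gives a readable value. The change to 4-fluorophenyl gives an at least 1.3-fold higher number from compound 3 to compound 4 (0.14 log units; that floor lies within the scatter), which means that a second halogen-bearing phenyl group does not simply match that readable value, although this floor cannot show whether the real step is small or large. The steps from compound 1 to compound 4 and from compound 2 to compound 4 cannot be read, because both ends of each step are limits, and the series now crowds at one end of the scale: the limit of > 300 mg/kg in this assay, at which 3 of the 4 values shown sit.

On these data alone, what true numbers compound 1, compound 2 and compound 4 would give stays open, so it remains unsettled whether compound 3 differs from any of them beyond the usual scatter. Also open, as far as these compounds go, is what a phenyl ring carrying an amine or a carboxylic acid would give at this place in this assay.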